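Adding a Methoxy to the Benzyl Arm of Compound 2

The source may hold more compounds than are shown below. What is called first, only, known or untested is meant among the compounds shown, and "the series" means these compounds.

Three measured compounds share one core and differ only in the chain and the amine that hang from it. Compound 1 `CCN(CCCCn1sc2cc(OC)c(OC)cc2c1=O)Cc1ccccc1` gives 19900 nM in an assay on isolated protein for inhibition of Amine oxidase [flavin-containing] A (Homo sapiens), read by fluorescence, with a stated time of 30 min; a lower number here means a stronger inhibitor, a higher number a weaker inhibitor. Compound 2 `COc1cc2sn(CCCCCCN(C)Cc3ccccc3)c(=O)c2cc1OC` gives 23000 nM in this assay, and compound 3 `CCN(CCCCCCn1sc2cc(OC)c(OC)cc2c1=O)Cc1ccccc1` gives 8200 nM. Going by the values given here, compound 2 thus carries the highest number of the three: it stands within the scatter of compound 1, and the only step beyond the scatter is a 2.8-fold lower number from compound 2 to compound 3 (0.45 log units; beyond the scatter), a modest change that comes from a methyl in place of hydrogen on a saturated chain carbon bound to the amine nitrogen.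

Compound 4 `COc1ccccc1CN(C)CCCCCCn1sc2cc(OC)c(OC)cc2c1=O` differs from compound 2 by methoxy in place of hydrogen on an aromatic carbon, ortho to a large group; read one bond further out, the benzyl becomes a 2-methoxybenzyl. Among the compounds with values here, no measured step touches that aromatic ring; the one step seen concerns the chain and the amine. There is therefore no basis for expecting a shift beyond the scatter. The step expected in this assay is a 1.2-fold lower number from compound 2 to compound 4 (0.06 log units; within the scatter), no larger than the scatter. Compound 4 is estimated at 20000 nM, with a range from 8000 nM to 50000 nM.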

Compound 4, half-maximal inhibitory concentration: 19900 nM
Compound 4: middle estimate off by 1.0-fold (0.00 log units), on the high side, and the stated range covers the measured number.
By their numbers in this assay, from the lowest: compound 3; then compounds 1, 4 and 2 (each within the scatter of the next).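

Going by these compounds alone, the one earlier step concerned the chain and the amine, so this result is the first look at the benzyl ring. In this assay, methoxy in place of hydrogen on an aromatic carbon, ortho to a large group, gives a 1.2-fold lower number from compound 2 to compound 4 (0.06 log units; within the scatter) and so produces no shift that can be told from the scatter: this ring carbon carries the methoxy with the number unmoved. No measured evidence available here accounts for this result.

Open, as far as these compounds go, is whether a different group on this same carbon, such as ethoxy, a carboxylic acid or an amine, would move the number beyond the scatter. Also open, from the compounds shown here alone, is whether methoxy would behave the same way on compound 3, which carries an ethyl on the amine nitrogen where compound 2 carries a methyl.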